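A few compounds are considered here, and "the series" means these few. Any claim that something is new, unique, unknown or untested is made for them only; others in the source may bear on it.

Working notes on the series, all read in a functional assay on MCF7 cells (Homo sapiens) for cytotoxicity, read by MTT assay, with a stated time of 72 h; on this read-out higher numbers stand for weaker inhibition and lower numbers for stronger inhibition. Going by the values given here, compound 1 (`COc1cc(/C=C/C(=O)Nc2cc3c(Nc4ccc(F)c(Cl)c4)ncnc3cc2O[C@H]2CCOC2)cc(OC)c1OC`) gives 28400 nM, the only number so far. Compound 2 (`COc1ccc(/C=C/C(=O)Nc2cc3c(Nc4ccc(F)c(Cl)c4)ncnc3cc2OC)cc1`) is recorded as "not active" (no number reported). Compound 3 (`COc1cc2ncnc(Nc3ccc(F)c(Cl)c3)c2cc1NC(=O)/C=C/c1ccc(C#N)cc1`) is recorded as "not active" (no number reported), so it has no single number and no exact place on the scale, and compound 2 shares that position.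

The next compound is compound 4 (`COc1cc2ncnc(Nc3ccc(F)c(Cl)c3)c2cc1NC(=O)/C=C/c1cc(OC)c(OC)c(OC)c1`). The change from compound 3 is 3,4,5-trimethoxyphenyl in place of 4-cyanophenyl on a double-bonded chain carbon bound to a double-bonded chain carbon.

The size of this step in this assay cannot be fixed, as compound 3 has no number to start from. The expected direction is toward stronger inhibition, but only as far as a weak measurable value, and another result without a number remains quite possible. The basis for this expectation is compound 1 at 28400 nM, which also carries 3,4,5-trimethoxyphenyl. For compound 4 the expected value is 25000 nM, with an estimated range of 9000 nM to 70000 nM.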

Compound 4, half-maximal inhibitory concentration: "not active" (no number reported)
Compound 4: no number reported, and the estimate cannot be compared.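

Compound 3 and compound 4 are both recorded as "not active" without a number, so no step can be read between them, and no measurement shown bears on this result. The compounds shown leave open whether 3,4,5-trimethoxyphenyl in place of 4-cyanophenyl changes inhibition at all.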